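The source may hold more compounds than are shown below. What is called first, only, known or untested is meant among the compounds shown, and "the series" means these compounds.

Two measured compounds anchor this part of the series. In a functional assay on SK-OV-3 cells (Homo sapiens) for cytotoxicity, read by MTT assay, with a stated time of 3 days (a lower number here means a stronger inhibitor, a higher number a weaker inhibitor), compound 1 `N#Cc1c(O)nc(SCc2nc3ccccc3[nH]2)nc1-c1ccccc1` gives 2.55 nM and compound 2 `N#Cc1c(Cl)nc(SCc2nc3ccccc3[nH]2)nc1-c1ccccc1` gives 3.37 nM. Compound 1 thus has a single neighbour on the numbers, and the two cannot be ordered. Next comes compound 3 `N#Cc1c(NN)nc(SCc2nc3ccccc3[nH]2)nc1-c1ccccc1`, with the change aminoamino in place of hydroxy on an aromatic carbon, ortho to a cyano group and next to the ring nitrogen. Within the data shown here, only one measured step bears on this change, chloro in place of hydroxy on an aromatic carbon: a 1.3-fold higher number from compound 1 to compound 2 (0.12 log units; within the scatter). On that single step, no shift beyond the scatter is expected in this assay. Among the measured compounds shown here, the range is kept wide, since no measured compound carries aminoamino and one step is thin evidence. The expected step is a 1.2-fold higher number from compound 1 to compound 3 (0.07 log units; within the scatter). For compound 3 the estimated value is 3 nM, with an expected range from 1 nM to 10 nM.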

Compound 3, half-maximal inhibitory concentration: 2.7 nM
Compound 3: the middle estimate sits 1.1-fold (0.05 log units) above what was measured, within the range that was stated.
By their numbers in this assay, from the lowest: compounds 1, 3 and 2 (each within the scatter of the next).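

In this assay, the position ortho to a cyano group and next to the ring nitrogen now carries a third kind of group, and the replacement of hydroxy by aminoamino stays within the scatter (a 1.1-fold higher number from compound 1 to compound 3 (0.02 log units; within the scatter)), as does the replacement of chloro by aminoamino (a 1.2-fold lower number from compound 2 to compound 3 (0.10 log units; within the scatter)). Hydroxy, chloro and aminoamino therefore cannot be told apart here, although aminoamino has 2 heavy atoms and 2 hydrogen-bond donors where hydroxy has 1 heavy atom and 1 hydrogen-bond donor, so in these three compounds neither that added atom nor that added donor goes with a shift beyond the scatter. No independent measurement is available to account for this lack of separation.

From the compounds shown here alone, whether a methoxy group, a morpholine ring or a longer alkylamine chain at this position would also stay within the scatter of compound 1 remains open. Also open, going by these compounds, is whether the three groups would remain indistinguishable if a pyridine or a cyclohexyl group stood in place of the phenyl group on the shared core.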